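Cytotoxicity of a thiazole analogue in the bicyclic amine series

This account rests on a few compounds, and the source may have more. Where it says the series, first, only, none or still open, it means among the compounds named here.

Compound 2 `C[C@H]1[C@H](NCc2ccoc2)C[C@H]2C[C@@H]1C2(C)C` carries a furan-3-yl on a saturated chain carbon bound to an amine nitrogen. In an ADME assay on MDCK cells (Canis lupus familiaris) for cytotoxicity, read by microscopy, with a stated time of 48 h (a lower number here means that less compound is tolerated, a higher number that more compound is tolerated), compound 2 reaches only the assay limit, > 100000 nM, so no number is known for it. Compound 1 `Cc1ccsc1CN[C@@H]1C[C@H]2C[C@@H]([C@H]1C)C2(C)C`, its 3-methylthiophen-2-yl counterpart, gives 10000 nM in this assay. Within the data shown here, the step of an at least 10-fold higher number from compound 1 to compound 2 (1.00 log units; beyond the scatter) is the only measured change and ends at the limit of > 100000 nM in this assay, at which 1 of the 2 values shown sits, so its full size is not known. Compound 3 `Cc1csc(CN[C@@H]2C[C@H]3C[C@@H]([C@H]2C)C3(C)C)n1` differs from compound 2 by 4-methyl-1,3-thiazol-2-yl in place of furan-3-yl on a saturated chain carbon bound to an amine nitrogen. Among the measured compounds shown here, no measured step covers this change directly; the one step to hand shows that the ring bearing a sulfur is tolerated less than the furan-3-yl. For compound 3 the expected step is an at least 2.0-fold lower number from compound 2 to compound 3 (0.30 log units; that floor lies within the scatter), toward a lower number than the limit seen for compound 2, with a real chance of a limit again. The estimate for compound 3 is 50000 nM, between 10000 nM and 150000 nM.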

Compound 3, minimum cytotoxic concentration: > 100000 nM
Compound 3: no number, only a limit (the forecaster's own chance of this, stated with the estimate: 40%); middle value at least 2.0-fold (0.30 log units) from the limit.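

In this assay compound 3 reaches only a limit, > 100000 nM, so carrying sulfur in the ring on a saturated chain carbon bound to an amine nitrogen does not by itself bring a measurable minimum cytotoxic concentration. Exchanging 3-methylthiophen-2-yl for 4-methyl-1,3-thiazol-2-yl gives an at least 10-fold higher number from compound 1 to compound 3 (1.00 log units; beyond the scatter), and compound 1 is now the only one of the three with a number, set apart from both other rings at this place. The step between the other two compounds cannot be read because both stop at the assay ceiling: the limit of > 100000 nM in this assay, at which 2 of the 3 values shown sit.

Whether the thiophene ring, its methyl group or both account for the value of compound 1 stays open; an unsubstituted thiophen-2-yl would separate these. Going by these compounds, how far compound 2 and compound 3 lie from each other also remains unknown.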